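The compounds below may be only part of what the source reports. "The series", "measured", "known", "first", "only" and "open" are said of these compounds alone.

Among the compounds with values here, compound 2 `CCC(CC)c1ccc2c(NCCCNCc3ccco3)ccnc2c1` is one of two compounds measured so far in a physicochemical assay for acid dissociation, and in this assay compound 2 gives 9.47. Within the data shown here, its only neighbour is compound 1 `Fc1ccc(-c2ccc3c(NCCCNCc4ccco4)ccnc3c2)cc1`, which in this assay gives 9.47, and the single measured step, no change at the digits printed from compound 1 to compound 2 (within the scatter), exchanged the group on the same aromatic carbon that is changed again below. Compound 3 `c1coc(CNCCCNc2ccnc3cc(-c4cccc5ccccc45)ccc23)c1` has not yet been measured, and its difference from compound 2 is naphthalen-1-yl in place of pentan-3-yl on an aromatic carbon. Among the measured compounds shown here, the one step that bears on this change, from a 4-fluorophenyl group to a pentan-3-yl group at that carbon, left the acid dissociation constant where it was, so a change at that carbon from pentan-3-yl to naphthalen-1-yl is expected to produce no step beyond the scatter, giving an expected no change at the digits printed from compound 2 to compound 3 (within the scatter). For compound 3 the estimated value in this assay is therefore 9.47, expected to fall between 9.17 and 9.77.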

Compound 3, acid dissociation constant: 9.47
Compound 3: the middle estimate sits on the measured number at the digits printed; measured number inside the range.
By their numbers in this assay, from the lowest: compounds 1, 2 and 3 (each within the scatter of the next).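

In this assay, naphthalen-1-yl, with its 10 heavy atoms and 2 six-membered aromatic rings, gives no change at the digits printed from compound 2 to compound 3 (within the scatter) and, set against the 4-fluorophenyl group, no change at the digits printed from compound 1 to compound 3 (within the scatter). This carbon has now carried an open group with no ring, a single aromatic ring and a fused pair of aromatic rings, and the read-out stays level across all three, so the earlier flat step was not limited to one pair of groups. No measurement shown here accounts for this flatness.

The compounds shown leave open whether an amine or a carboxylic acid at this same carbon would also stay level with these three. They also leave open whether a longer chain elsewhere on the shared core would move the number.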